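Swapping a methyl for two chlorines on the pendant ring

The compounds below may be only part of what the source reports. "The series", "measured", "known", "first", "only" and "open" are said of these compounds alone.

The three measured compounds share one core and differ only in the aryl group on the double-bonded chain carbon. Compound 1 `C=CCn1c(=O)/c(=C\c2ccc(F)c(Br)c2)[nH]c(=O)/c1=C\c1ccccc1OC` in a functional assay on K562 cells (Homo sapiens) for cytotoxicity, read by CCK-8 assay, with a stated time of 72 h (a higher number here means a weaker inhibitor, a lower number a stronger inhibitor), is recorded as "not active" (no number reported). Compound 2 `C=CCn1c(=O)/c(=C\c2ccccc2F)[nH]c(=O)/c1=C\c1ccccc1OC` in this assay gives 5600 nM, the only numerical result in the set. Compound 3 `C=CCn1c(=O)/c(=C\c2ccc(C)cc2)[nH]c(=O)/c1=C\c1ccccc1OC` in this assay is likewise recorded as "not active" (no number reported), so compound 3 stands without a single number, and one further compound, compound 1, shares that position.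

Compound 4 `C=CCn1c(=O)/c(=C\c2ccc(Cl)c(Cl)c2)[nH]c(=O)/c1=C\c1ccccc1OC` is not yet measured. Its change from compound 3 is 3,4-dichlorophenyl in place of 4-methylphenyl on a double-bonded chain carbon bound to an aromatic carbon. Within the data shown here, no measured step exists between these two compounds, and compound 3 itself has no number, so the size of the step in this assay cannot be anchored; the nearest comparison is compound 1, which also carries a disubstituted ring and is recorded as "not active" (no number reported). Compound 4 is therefore expected to remain weak in this assay, with a considerable chance that only an inactive call is reported. The estimate for compound 4 in this assay is 20000 nM, within a range from 5000 nM to 80000 nM.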

Compound 4, half-maximal inhibitory concentration: "not active" (no number reported)
Compound 4 has no reported number here; there is nothing to compare the estimate with.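

In this assay compound 3 is recorded as "not active" (no number reported) and compound 4 as "not active" (no number reported), so no step can be read between compound 3 and compound 4. Nothing shown here bears on the reason for this result. The compounds shown leave open whether 3,4-dichlorophenyl and 4-methylphenyl differ at all in this assay.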